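Nitro in place of cyano: compound 2 to compound 3

The compounds below may be only part of what the source reports. "The series", "measured", "known", "first", "only" and "open" are said of these compounds alone.

Of the compounds shown here, two have numbers so far in a functional assay on VCaP cells (Homo sapiens) for antiproliferative activity, read by propidium iodide staining, with a stated time of 96 h (a higher number here means a weaker inhibitor, a lower number a stronger inhibitor), and both sit high. Here compound 1 `CC(O)(COc1ccc(S(F)(F)(F)(F)F)cc1)C(=O)Nc1ccc([N+](=O)[O-])c(C(F)(F)F)c1` reads 100000 nM and compound 2 `CC(O)(COc1ccc(S(F)(F)(F)(F)F)cc1)C(=O)Nc1ccc(C#N)cc1C(F)(F)F` reads 25500 nM as the lower of the two. That gap lies beyond the usual scatter, so compound 2 is the stronger inhibitor of this pair, though still at a high number.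

The next step leads to compound 3 `CC(O)(COc1ccc(S(F)(F)(F)(F)F)cc1)C(=O)Nc1ccc([N+](=O)[O-])cc1C(F)(F)F` with nitro in place of cyano on an aromatic carbon, meta to a trifluoromethyl group and para to a large group, with nitro in place of cyano on an aromatic carbon as the whole of the change.

Among the measured compounds shown here, no measured pair isolates this swap, so the size of the step in this assay can only be judged loosely. For the measured compounds named here, compound 1, the only measured compound carrying nitro, sits at 100000 nM on the weak side, which points to a small loss rather than a gain. The estimated change is a 1.8-fold higher number from compound 2 to compound 3 (0.25 log units; within the scatter) and is expected to be a small move toward a higher number, not clearly beyond the scatter. Compound 3 is expected at 45000 nM with an estimated range of 18000 nM to 100000 nM for now.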

Compound 3, half-maximal inhibitory concentration: 26100 nM
Estimate against measurement, compound 3: 1.7-fold (0.24 log units) above; low and high end bracket the measured number.
By their numbers in this assay, from the lowest: compounds 2 and 3 (each within the scatter of the next); then compound 1.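

In this assay, nitro in place of cyano on this aromatic carbon, meta to a trifluoromethyl group and para to a large group, gives a 1.0-fold higher number from compound 2 to compound 3 (0.01 log units; within the scatter), so at this position the two groups cannot be told apart in this read-out. Among the compounds shown here, this is the first direct reading of the swap, as the earlier compounds offered no pair differing in one place; compound 1 also carries nitro but differs from compound 2 and compound 3 in more than one place, so it says nothing about this swap. No measurement shown here accounts for the two groups reading alike.

Going by these compounds, compound 2 and compound 3 both remain at high numbers, so it is open whether any group at this aromatic carbon, such as an amine, a carboxylic acid or a primary amide, would move the read-out beyond the scatter. Also open, on these data alone, is whether the nitrile and nitro groups would still read alike with a chlorine atom or a methyl group in place of the trifluoromethyl group.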